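A few compounds are considered here, and "the series" means these few. Any claim that something is new, unique, unknown or untested is made for them only; others in the source may bear on it.

Measured so far:
- compound 1 `Oc1ccc(-c2nc3ccccc3s2)cc1O`: 15600 nM
- compound 2 `COc1ccc(-c2nc3cc(F)ccc3s2)cc1`: 24600 nM

In a functional assay on KM12 cells (Homo sapiens) for antiproliferative activity (a lower number here means a stronger inhibitor of growth, a higher number a weaker inhibitor of growth), compound 1 gives 15600 nM and compound 2 gives 24600 nM, so the two values lie within the scatter of each other. Compound 3 `Oc1ccc(-c2nc3cc(F)ccc3s2)cc1O` is the next step from compound 1, with this change: fluoro in place of hydrogen on an aromatic carbon. Within the data shown here, no measured pair isolates this change, so nothing points to a direction in this assay. The expected change, a 1.0-fold lower number from compound 1 to compound 3 (0.02 log units; within the scatter), is none beyond the scatter. For compound 3 the estimated value is 15000 nM, with an expected range of 6000 nM to 35000 nM.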

Compound 3, concentration for 50% growth inhibition: 13000 nM
The estimate for compound 3 lay 1.2-fold (0.06 log units) above the measured number; the measured number falls inside the stated range.
By their numbers in this assay, from the lowest: compounds 3, 1 and 2 (each within the scatter of the next).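

In this assay, fluoro in place of hydrogen on an aromatic carbon of the fused system gives a 1.2-fold lower number from compound 1 to compound 3 (0.08 log units; within the scatter) and thus lies within the scatter. This single matched pair gives the series its first reading at this position: with the rest of compound 1 unchanged, this change produces no shift that can be distinguished from the scatter. No supporting evidence bears on this result. Still open, from the compounds shown here alone, is whether an amine, a carboxylic acid or a longer chain at this place would move the number beyond the scatter. Going by these compounds, whether fluoro behaves the same way on other cores also remains open.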